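A few compounds are considered here, and "the series" means these few. Any claim that something is new, unique, unknown or untested is made for them only; others in the source may bear on it.

Measured compounds in a functional assay on SK-BR-3 cells (Homo sapiens) for antiproliferative activity, read by MTT assay, with a stated time of 72 h; on this read-out lower numbers stand for stronger inhibition and higher numbers for weaker inhibition:
- compound 1 `CCc1ccc(C(=O)Nc2ccc3nc(N4CCN(CC)CC4)cc(C)c3c2)cc1`: 9850 nM
- compound 2 `CCc1ccccc1C(=O)Nc1ccc2nc(N3CCN(CC)CC3)cc(C)c2c1`: 23900 nM
- compound 3 `CCN1CCN(c2cc(C)c3cc(NC(=O)c4ccc(F)cc4)ccc3n2)CC1`: 19800 nM

Compound 2 gives the highest of the three numbers. Its nearest neighbour is compound 3, a 1.2-fold lower number from compound 2 to compound 3 (0.08 log units; within the scatter), a gap within the scatter; its furthest is compound 1, a 2.4-fold higher number from compound 1 to compound 2 (0.38 log units; beyond the scatter), a modest step beyond the scatter.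

Compound 4 `CCN1CCN(c2cc(C)c3cc(NC(=O)c4ccccc4OC)ccc3n2)CC1` differs from compound 2 in one place: methoxy in place of ethyl on an aromatic carbon. The substituent stays on the same aromatic carbon of the benzamide ring, so the change is a swap of one small group for another rather than a move around the ring.

Within the data shown here, no measured step covers a methoxy group anywhere. The steps that come nearest are a 2.4-fold higher number from compound 1 to compound 2 (0.38 log units; beyond the scatter), which shifts an ethyl group from one aromatic carbon to another, and a 2.0-fold higher number from compound 1 to compound 3 (0.30 log units; within the scatter), which swaps ethyl for fluoro and stays within the scatter. Taken together they suggest that small changes at the benzamide ring move this assay by at most a modest amount, and that a different small group on the same carbon as in compound 2 is unlikely to break out of the scatter. The step of a 1.2-fold lower number from compound 2 to compound 4 (0.08 log units; within the scatter) is therefore expected to be small, with no clear direction. Compound 4 is estimated at 20000 nM, within a range of 8000 nM to 50000 nM.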

Compound 4, half-maximal inhibitory concentration: 15700 nM
The estimate for compound 4 lay 1.3-fold (0.11 log units) above the measured number, within the range that was stated.
By their numbers in this assay, from the lowest: compounds 1, 4, 3 and 2 (each within the scatter of the next, the first and the last beyond it).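

Working notes on the benzamide ring: in this assay, methoxy on the aromatic carbon ortho to a large group, where compound 2 carries ethyl, gives a 1.5-fold lower number from compound 2 to compound 4 (0.18 log units; within the scatter), so this position accepts an oxygen-linked group of the same heavy-atom size, counted as a hydrogen-bond acceptor, without a shift that can be read. Among these compounds, the 2-methoxyphenyl amide also stays unresolved from the two other aryl amides, with a 1.3-fold lower number from compound 3 to compound 4 (0.10 log units; within the scatter) and a 1.6-fold higher number from compound 1 to compound 4 (0.20 log units; within the scatter), whereas a 2.4-fold higher number from compound 1 to compound 2 (0.38 log units; beyond the scatter) is the only step in the set printed as beyond the scatter, so the gap between 4-ethylphenyl and an ortho-substituted ring holds for 2-ethylphenyl and does not carry over to 2-methoxyphenyl. No measurement at hand bears on why these numbers fall as they do.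

Still open, as far as these compounds go, is how methoxy behaves on another ring carbon, since a 4-methoxyphenyl partner would be needed to set against the ethyl pair. Also open, from the compounds shown here alone, is whether an amine, a carboxylic acid or a longer chain such as butyl on this same carbon would move the number beyond the scatter in either direction.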